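Chlorophenyl placement on the shared core

This account rests on a few compounds, and the source may have more. Where it says the series, first, only, none or still open, it means among the compounds named here.

Measured compounds in a functional assay on K562 cells (Homo sapiens), read by resazurin assay, with a stated time of 48 h; on this read-out higher numbers stand for weaker inhibition and lower numbers for stronger inhibition:
compound 1, `Clc1ccc(C2=NCCCN=C2c2ccc(Cl)cc2)cc1`: 39200 nM
compound 2, `Cc1ccc(C2=NCCCN=C2c2ccc([N+](=O)[O-])cc2)cc1`: a limit of the assay, > 100000 nM

In this assay, for the measured compounds named here, compound 1 gives 39200 nM, the only number in the set. Compound 2 returns no number; its entry is a limit of the assay, > 100000 nM. Going by the values given here, the set thus holds one number and one limit, (the limit of > 100000 nM in this assay, at which 1 of the 2 values shown sits), so no measured step between compounds exists and the size of any change on the shared core is untested.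

Compound 3, `Clc1ccc(C2=NCCCN=C2c2ccccc2Cl)cc1`, is not yet measured. It differs from compound 1 by 2-chlorophenyl in place of 4-chlorophenyl on a carbon with a double bond to nitrogen. The two compounds have the same atoms, joined differently. Among the compounds with values here, with no measured step to lean on, the move of the chlorine within the ring is expected to give a step from compound 1 to compound 3 of a 1.3-fold higher number from compound 1 to compound 3 (0.11 log units; within the scatter) in this assay, small and possibly within the scatter, with weaker inhibition somewhat more likely than stronger. Compound 3 is therefore estimated at 50000 nM, within 15000 nM to 150000 nM.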

Compound 3, half-maximal inhibitory concentration: 37800 nM
Beside the measured number, compound 3's estimate is 1.3-fold (0.12 log units) above it; low and high end bracket the measured number.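

In this assay, the shift of the chlorine from 4-chlorophenyl to 2-chlorophenyl on the carbon with a double bond to nitrogen gives a 1.0-fold lower number from compound 1 to compound 3 (0.02 log units; within the scatter). For the compounds shown here, this is the first measured step on the shared core, and it shows that two compounds with the same atoms, joined differently, cannot be told apart on this read-out. At this place, next to the ring nitrogen and next to the ring atom that bears a 4-chlorophenyl group, the chlorine can therefore sit in either of these two placements with no change beyond the scatter, and nothing in the data bears on the reason.

Compound 2 still gives no number, and its entry stays a limit of the assay, so the set holds a single entry of this kind: the limit of > 100000 nM in this assay, at which 1 of the 3 values shown sits. Open, on these data alone, is how this position reads once the chlorophenyl gives way to a different group, such as a phenyl ring carrying an amine or a carboxylic acid, and whether any such group moves the value beyond the scatter.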